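Ring-Nitrogen Substitution Repeated on a Second Core

The source may report more compounds than this note shows. Statements on the series, on what has been measured and on what is new or still open speak of the compounds shown alone.

Compound 1 `O=C1COc2ccc(-c3cccc(NS(=O)(=O)c4ccc(F)cc4)c3)cc2N1`: 18300 nM
Compound 2 `O=C1COc2ccc(-c3cccc(NS(=O)(=O)c4ccc(F)cc4)c3)cc2N1c1ccc(Cl)cc1`: 39800 nM
Compound 3 `O=C1COc2ccc(-c3cnc4ccccc4c3)cc2N1`: > 40000 nM

In a functional assay on MCF7 cells (Homo sapiens) for antiproliferative activity, read by MTT assay, with a stated time of 72 h (a higher number here means a weaker inhibitor, a lower number a stronger inhibitor), compound 1 gives 18300 nM. Compound 2 differs by 4-chlorophenyl in place of hydrogen on an amide-type nitrogen in a ring and gives 39800 nM, so a 2.2-fold higher number from compound 1 to compound 2 (0.34 log units; beyond the scatter). For compound 3 the result is only a limit of this assay, namely > 40000 nM, at the limit of > 40000 nM in this assay, at which 1 of the 3 values shown sits. The difference between the core of compound 3 and the core of compound 1 is not broken down here. Compound 4 `O=C1COc2ccc(-c3cnc4ccccc4c3)cc2N1c1ccc(Cl)cc1` is not yet measured; it differs from compound 3 by 4-chlorophenyl in place of hydrogen on an amide-type nitrogen in a ring, the same change at the same place as between compound 1 and compound 2. Since a 2.2-fold higher number from compound 1 to compound 2 (0.34 log units; beyond the scatter) moved the number higher, compound 4 is expected to remain at or beyond the limit, with an expected step that the limit leaves unreadable from compound 3 to compound 4. Compound 4 is estimated at 80000 nM, between 40000 nM and 200000 nM.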

Compound 4, half-maximal inhibitory concentration: > 40000 nM
Compound 4 ended at the assay's limit; the forecaster's own chance of this, stated with the estimate: 85%; the middle value lies beyond the limit too.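

Among the compounds shown here, compound 3 and compound 4 are both recorded only as limits in this assay, so no step between them can be read: the limit of > 40000 nM in this assay, at which 2 of the 4 values shown sit.

The compounds shown leave open whether 4-chlorophenyl on the ring nitrogen raises the number on the core of compound 3, as it did on the core of compound 1.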